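Ethoxy Where Chloro Once Stood: An Expected Binding Value

The source may report more compounds than this note shows. Statements on the series, on what has been measured and on what is new or still open speak of the compounds shown alone.

Compound 1 `CCc1nc(NC(CC)CC)c(Cl)nc1-c1ccc(Cl)cc1Cl`: 71 nM
Compound 2 `CCc1nc(NC(CC)CC)cnc1-c1ccc(Cl)cc1Cl`: 545 nM

Both were tested in an assay on IMR-32 cells for displacement of a labelled ligand from corticotropin-releasing factor receptor 1 (Homo sapiens), read by scintillation counting, with a stated time of 2 h; a lower number here means a stronger inhibitor, a higher number a weaker inhibitor. Among the measured compounds shown here, compound 2 stands at the higher of the two numbers; the single measured step is a 7.7-fold higher number from compound 1 to compound 2 (0.89 log units; beyond the scatter). Compound 3 `CCOc1nc(-c2ccc(Cl)cc2Cl)c(CC)nc1NC(CC)CC` differs from compound 2 by ethoxy in place of hydrogen on an aromatic carbon. The ethoxy enters at the carbon where compound 1 carried chloro, so that step is the one bearing on it: modest, and beyond the scatter. Filling this place again is expected to lower the number, though by less than the chloro did. For compound 3 the estimate is 160 nM, range 45 nM to 600 nM, meaning a 3.4-fold lower number from compound 2 to compound 3 (0.53 log units; beyond the scatter).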

Compound 3, inhibition constant: 151 nM
Estimate against measurement, compound 3: 1.1-fold (0.03 log units) above; low and high end bracket the measured number.
By their numbers in this assay, from the lowest: compound 1; then compound 3; then compound 2.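

In this assay, ethoxy at this carbon also lowers the number (a 3.6-fold lower number from compound 2 to compound 3 (0.56 log units; beyond the scatter)), so the gain from filling this place is not unique to chloro. Ethoxy does not fully match chloro, though, as swapping one for the other shows (a 2.1-fold higher number from compound 1 to compound 3 (0.33 log units; beyond the scatter)). Nothing available here explains either difference. Going by these compounds, whether a shorter methoxy group, a longer propoxy chain or an amine at this carbon would match chloro remains open. So does whether ethoxy would have the same effect with another group in place of the (pentan-3-yl)amino group.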